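Methoxy for isopropoxy on the shared core

The compounds below may be only part of what the source reports. "The series", "measured", "known", "first", "only" and "open" are said of these compounds alone.

Three members of the series have been measured in a functional assay on CHO cells for agonist activity at sphingosine 1-phosphate receptor 5 (Homo sapiens), read by GTPgammaS binding; on this read-out higher numbers stand for an effect only at larger amounts of compound and lower numbers for an effect already at smaller amounts. Compound 1 `Cc1ccccc1-c1noc(-c2ccc(C3CCCCC3)cc2)n1` gives 266 nM. Compound 2 `Cc1cc(C(=O)O)ccc1-c1noc(-c2ccc(C3CCCCC3)cc2)n1` reaches only the limit > 10000 nM, so no number is known for it. Compound 3 `Cc1cc(CCC(=O)O)ccc1-c1noc(-c2ccc(OC(C)C)c(C(F)(F)F)c2)n1` gives 40 nM, the lowest of the two numbers available; compound 1 stands nearest to it, and the gap between the two is beyond the scatter. For the measured compounds named here, the one step between compounds that differ in a single place, an at least 37-fold higher number from compound 1 to compound 2 (1.57 log units; beyond the scatter), concerns carboxy in place of hydrogen on an aromatic carbon and rests on a limit (the limit of > 10000 nM in this assay, at which 1 of the 3 values shown sits).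

Compound 4 `COc1ccc(-c2nc(-c3ccc(CCC(=O)O)cc3C)no2)cc1C(F)(F)F` differs from compound 3 by methyl in place of isopropyl on an oxygen on an aromatic ring. Going by the values given here, no measured pair in this set alters a group on an ether oxygen, and the step from compound 1 to compound 2 touches a different part of the molecule, so it offers no guidance for this change. With nothing pointing either way, the step of a 2.0-fold higher number from compound 3 to compound 4 (0.30 log units; within the scatter) is expected to be small and probably within the scatter, if anything a slightly higher number. Compound 4 is therefore estimated at 80 nM, with a range from 25 nM to 300 nM.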

Compound 4, half-maximal effective concentration: 2600 nM
Estimate against measurement, compound 4: 33-fold (1.51 log units) below; measured number above the stated range.
By their numbers in this assay, from the lowest: compound 3; then compound 1; then compound 4. At a limit, above all of these: compound 2.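

In this assay, the group on the ether oxygen is a place where a single change carries a large effect with the rest of the molecule held constant: a 65-fold higher number from compound 3 to compound 4 (1.81 log units; beyond the scatter). The exchange is modest by count, with isopropyl (3 heavy atoms) leaving and methyl (1 heavy atom) entering, and neither group brings a ring, a hydrogen-bond donor, a hydrogen-bond acceptor or a net charge. Unlike the one earlier step, which rests on a limit, this step is read between two actual numbers, so its full size is known.

Nothing among the compounds shown gives a reason for the size of this step. Open, from the compounds shown here alone, is where between methyl and isopropyl the number turns, which ethoxy or a propoxy chain on the same oxygen would settle, and whether a tert-butyl group or a cyclopentyl ring there would bring the number lower still or send it back up.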